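The source may report more compounds than this note shows. Statements on the series, on what has been measured and on what is new or still open speak of the compounds shown alone.

Compound 1 `Cc1cc(C)c(/C=C/c2ncc([N+](=O)[O-])n2C)c(C)c1`: 11000 nM
Compound 2 `Cn1c([N+](=O)[O-])cnc1/C=C/c1cccc(Br)c1`: 87100 nM
Compound 3 `Cn1c([N+](=O)[O-])cnc1/C=C/c1ccc(Cl)cc1Cl`: > 100000 nM

All three compounds were tested in an ADME assay on HeLa cells (Homo sapiens) for cytotoxicity, read by resazurin assay, with a stated time of 2 days; a lower number here means a stronger inhibitor, a higher number a weaker inhibitor. For compound 3, the reading of > 100000 nM is a limit of the assay and not a number. That leaves two true numbers to compare. Compound 2, at 87100 nM, has the higher of them. The nearest value belongs to compound 1, at 11000 nM, and the gap between them lies beyond the usual scatter of repeated measurements.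

The next compound to be measured is compound 4 `Cn1c([N+](=O)[O-])cnc1/C=C/c1cccc(F)c1`. It differs from compound 2 at a single place: fluoro in place of bromo on an aromatic carbon. This is fluoro in place of bromo on an aromatic carbon, meta to a large group. For the measured compounds named here, no pair of measured compounds shows this swap on its own, so the expectation rests mainly on the standing of compound 2 at 87100 nM. Going by the values given here, with only one small group exchanged for another, no shift beyond the scatter is expected in this assay. The estimated change is a 1.5-fold lower number from compound 2 to compound 4 (0.16 log units; within the scatter), and a result outside the scatter in either direction would not be a surprise. Compound 4 is expected at about 60000 nM, with an estimated range from 18000 nM to 150000 nM.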

Compound 4, half-maximal inhibitory concentration: > 100000 nM
Compound 4 was reported as a limit; the forecaster's own chance of this, stated with the estimate: 30%; middle value at least 1.6-fold (0.22 log units) from the limit.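

Fluoro in place of bromo, on the aromatic carbon meta to a large group, gives in this assay an at least 1.1-fold higher number from compound 2 to compound 4 (0.05 log units; that floor lies within the scatter). From the compounds shown here alone, the value of compound 4, > 100000 nM, is a limit of the assay and not a number, so the true size of this step stays unknown, and its floor alone cannot tell the swap apart from no change at all. What this adds is that, at this place on the ring, fluoro gives no sign of a stronger effect on these cells than bromo does, and the reading ends at the top of what can be reported: the limit of > 100000 nM in this assay, at which 2 of the 4 values shown sit.

The compounds shown leave open how a group that is not a halogen would read at this place, such as an amine, a methoxy group or a carboxylic acid, and whether any of these would give a clearly lower number than compound 2 in this assay. Also open, going by these compounds, is how far the true reading of compound 4 lies past its limit, which would take testing at higher concentrations to settle.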